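Nitro removal on the benzyloxy arm, two isomers compared

A few compounds are considered here, and "the series" means these few. Any claim that something is new, unique, unknown or untested is made for them only; others in the source may bear on it.

Measured so far:
compound 1, `O=[N+]([O-])c1ccc(COc2ccc(Nc3ncnc4cc5c(cc34)OCCOCCO5)cc2)cc1`, > 100000 nM
compound 2, `c1ccc(COc2ccc(Nc3ncnc4cc5c(cc34)OCCOCCO5)cc2)cc1`, 55500 nM
compound 3, `O=[N+]([O-])c1ccc(COc2cccc(Nc3ncnc4cc5c(cc34)OCCOCCO5)c2)cc1`, 65300 nM

In a functional assay on HepG2 cells (Homo sapiens) for antiproliferative activity, read by MTT assay, with a stated time of 72 h (on this read-out higher numbers stand for weaker inhibition and lower numbers for stronger inhibition), compound 1 gives > 100000 nM, which is a limit of the assay (the limit of > 100000 nM in this assay, at which 1 of the 3 values shown sits). Compound 2 gives 55500 nM and compound 3 gives 65300 nM in this assay; the two values lie within the scatter of each other. Within the data shown here, the one measured step, an at least 1.8-fold lower number from compound 1 to compound 2 (0.25 log units; that floor lies within the scatter), comes from the change (hydrogen in place of nitro on an aromatic carbon). How compound 3 differs from compound 1 is not broken down here.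

Compound 4, `c1ccc(COc2cccc(Nc3ncnc4cc5c(cc34)OCCOCCO5)c2)cc1`, is not yet measured. It carries the same change relative to compound 3, (hydrogen in place of nitro on an aromatic carbon), at the same place.

The expected step of a 1.6-fold lower number from compound 3 to compound 4 (0.21 log units; within the scatter) rests on the measured step of an at least 1.8-fold lower number from compound 1 to compound 2 (0.25 log units; that floor lies within the scatter), whose floor lies within the scatter. Compound 4 is therefore expected near 40000 nM, between 15000 nM and 100000 nM.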

Compound 4, half-maximal inhibitory concentration: > 100000 nM
Compound 4: only a limit was reported; the forecaster's own chance of this, stated with the estimate: 10%; at least 2.5-fold (0.39 log units) between middle value and limit.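

In this assay compound 4 gives > 100000 nM, which is a limit of the assay and not a number: the limit of > 100000 nM in this assay, at which 2 of the 4 values shown sit. The change from 4-nitrobenzyl to benzyl gives an at least 1.5-fold higher number from compound 3 to compound 4 (0.18 log units; that floor lies within the scatter), so its effect on the core of compound 1 does not carry over to the core of compound 3: the same change on two cores in this assay, an at least 1.8-fold lower number (0.25 log units; that floor lies within the scatter) from compound 1 to compound 2 and an at least 1.5-fold higher number (0.18 log units; that floor lies within the scatter) from compound 3 to compound 4, at least 2.7-fold (0.44 log units) apart, beyond the scatter of two such steps. Both steps rest on a limit; their true sizes remain unknown, and the data give no reason for the difference.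

As far as these compounds go, it remains open whether an amine or a carboxylic acid in place of the nitro would show the same split between the two cores. Also open, from the compounds shown here alone, is whether a longer chain in place of the benzyl would bring values clear of the limit.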